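Nitro to cyano swap at the aryl ketone end

The source may report more compounds than this note shows. Statements on the series, on what has been measured and on what is new or still open speak of the compounds shown alone.

Two compounds of the series have been run in a functional assay on SR cells (Homo sapiens) for inhibition, read by sulforhodamine B assay, with a stated time of 48 h, tested at 10 uM; on this read-out lower numbers stand for less inhibition of growth and higher numbers for more inhibition of growth at the one concentration tested. Compound 1 `CC(=O)c1ccc(Nc2ccnc(SCC(=O)c3ccc(Br)cc3)n2)cc1` gives 25%. Compound 2 `CCOC(=O)c1ccc(Nc2ccnc(SCC(=O)c3ccc([N+](=O)[O-])cc3)n2)cc1` gives 35%. Compound 2 holds the highest of the two numbers shown, but compound 1 is its nearest neighbour and the gap between the two lies within the usual scatter, so no order between them can be claimed.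

Compound 3 `CCOC(=O)c1ccc(Nc2ccnc(SCC(=O)c3ccc(C#N)cc3)n2)cc1` is not yet measured. It differs from compound 2 by cyano in place of nitro on an aromatic carbon. For the measured compounds named here, no step between measured compounds in this assay bears on this change, so the data give no direction for it. With both measured neighbours at modest inhibition, compound 3 is expected to stay in the same region, with an expected step of a number 5 percentage points lower from compound 2 to compound 3 (within the scatter) that does not go beyond the scatter. The estimate for compound 3 in this assay is 30%, in a range from 12% to 50%.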

Compound 3, percent growth inhibition at one concentration: 46%
Compound 3: the middle estimate sits 16 percentage points below what was measured; measured number inside the range.
By their numbers in this assay, from the lowest: compounds 1 and 2 (each within the scatter of the next); then compound 3.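

In this assay, for the compounds shown here, the exchange of nitro for cyano, on an aromatic carbon para to a large group, gives a number 11 percentage points higher from compound 2 to compound 3 (beyond the scatter), the first step that can be read at one place. The aryl ketone end therefore responds to a change of this substituent, and the nitro group of compound 2 is not required for the inhibition of growth seen in this pair. No measured data on the two groups offer an account of this step.

A single pair gives a direction for these two groups only, and that direction rests on one concentration in one cell line. On these data alone, whether an amine, a carboxylic acid or a methoxy group at this place would extend the step remains open, as does whether the same exchange holds with an acetyl group in place of the ethyl ester.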